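The compounds below may be only part of what the source reports. "The series", "measured", "known", "first", "only" and "open" are said of these compounds alone.

Of the compounds shown here, three of a shared core have been measured in a functional assay on CCRF-CEM cells (Homo sapiens) for inhibition; a higher number here means a weaker inhibitor, a lower number a stronger inhibitor. Compound 1 `Cc1cc(-c2ncnc3c2ncn3C2O[C@H](CO)[C@@H](O)[C@H]2O)on1` gives "not active" (no number reported) in this assay. Compound 2 `OC[C@H]1OC(n2cnc3c(-c4cc5ccccc5o4)ncnc32)[C@H](O)[C@@H]1O` gives 15000 nM. Among the measured compounds shown here, compound 3 `OC[C@H]1OC(n2cnc3c(-c4ccco4)ncnc32)[C@H](O)[C@@H]1O` gives 600 nM, the lowest of the two numbers obtained; its nearest measured neighbour is compound 2, and the step of a 25-fold lower number from compound 2 to compound 3 (1.40 log units; beyond the scatter) is the only measured step available. Compound 4 `OC[C@H]1OC(n2cnc3c(-c4ccsc4)ncnc32)[C@H](O)[C@@H]1O` differs from compound 3 in one place: thiophen-3-yl in place of furan-2-yl on an aromatic carbon. For the measured compounds named here, no measured pair shows this particular exchange, so the expectation is guarded. Going by the values given here, because the single measured step of a 25-fold lower number from compound 2 to compound 3 (1.40 log units; beyond the scatter) was large, a change of the aromatic group at this place can move the number far; yet the entering and leaving groups here are alike in ring size and in count of hetero atoms, so a step within the scatter, perhaps a slight rise, is the expected outcome. The estimate for compound 4 in this assay is 900 nM, expected to fall between 250 nM and 3500 nM, a step of a 1.5-fold higher number from compound 3 to compound 4 (0.18 log units; within the scatter).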

Compound 4, half-maximal inhibitory concentration: 1640 nM
Compound 4: middle estimate off by 1.8-fold (0.26 log units), on the low side; low and high end bracket the measured number.
By their numbers in this assay, from the lowest: compound 3; then compound 4; then compound 2.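

In this assay, the step of a 2.7-fold higher number from compound 3 to compound 4 (0.44 log units; beyond the scatter) shows that this place responds even when one five-membered aromatic ring with 1 hetero atom replaces another with the same heavy-atom count, so matching size and counts does not make two groups interchangeable here. The step of a 9.1-fold lower number from compound 2 to compound 4 (0.96 log units; beyond the scatter) shows that furan-2-yl is not the only single five-membered ring to give a lower number than 1-benzofuran-2-yl. No measurement at hand explains the difference between the oxygen ring and the sulfur ring.

This exchange changes both the hetero atom and the ring carbon that carries the bond to the core, and the compounds shown cannot separate the two. As far as these compounds go, how thiophen-2-yl, furan-3-yl or a non-ring group such as an amine would behave at this place remains open.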